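The source may hold more compounds than are shown below. What is called first, only, known or untested is meant among the compounds shown, and "the series" means these compounds.

Compound 1 `C=CC1=C(C(=O)NCCCCC)C(c2ccc(F)cc2)OC1`: in a functional assay on HeLa cells (Homo sapiens) for cytotoxicity, read by MTT assay, with a stated time of 24 h (on this read-out higher numbers stand for weaker inhibition and lower numbers for stronger inhibition), compound 1 gives > 100000 nM, a limit of the assay rather than a number.
Compound 2 `C=CC1=C(C(=O)NCc2ccc(Cl)cc2)C(c2ccc(F)cc2)OC1`: in this assay compound 2 gives > 100000 nM, likewise a limit of the assay.

Compound 1 thus stands at the limit of > 100000 nM in this assay, at which 2 of the 2 values shown sit. Within the data shown here, the one measured step, a step that the two limits leave unreadable from compound 1 to compound 2, cannot be read, since both ends are limits. Compound 3 `C=CC1=C(C(=O)O)C(c2ccc(F)cc2)OC1` differs from compound 1 by hydroxy in place of pentylamino on a carbonyl carbon. Among the measured compounds shown here, no measured step bears on this change, so no size or direction beyond the scatter can be expected from the data. Compound 3 is therefore estimated to give 150000 nM (from 50000 nM to 500000 nM), a step that the limit leaves unreadable from compound 1 to compound 3 that would most likely again be reported only as a limit.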

Compound 3, half-maximal inhibitory concentration: 67400 nM
Compound 3: middle estimate off by 2.2-fold (0.35 log units), on the high side; the range from low to high includes it.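

In this assay, among these compounds, hydroxy in place of pentylamino on a carbonyl carbon gives an at least 1.4-fold lower number from compound 1 to compound 3 (0.17 log units; that floor lies within the scatter) and so provides the only readable step at this position. That step is a floor and may be larger, but it does not establish a change beyond the scatter. Compound 3 is the one compound shown with a number rather than a limit of the assay: the limit of > 100000 nM in this assay, at which 2 of the 3 values shown sit.

The compounds shown leave open how a primary amide or a methyl ester at this carbonyl carbon would read. They also leave open whether a shorter chain on the amide nitrogen would bring a value below the limit.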